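A few compounds are considered here, and "the series" means these few. Any claim that something is new, unique, unknown or untested is made for them only; others in the source may bear on it.

Measured in a functional assay on PC-3 cells (Homo sapiens) for antiproliferative activity, read by MTT assay, with a stated time of 72 h; a higher number here means a weaker inhibitor, a lower number a stronger inhibitor:
Compound 1 `O=C(N/N=C/c1ccc(Cl)c(Cl)c1)Nc1ccc(Oc2ccnc3[nH]ccc23)c(F)c1`: 14100 nM
Compound 2 `O=C(N/N=C/c1ccc(O)cc1)Nc1ccc(Oc2ccnc3[nH]ccc23)c(F)c1`: 2780 nM
Compound 3 `O=C(N/N=C/c1ccc(O)cc1)Nc1ccc(Oc2ccnc3[nH]ccc23)cc1`: 4920 nM

Compound 3 gives 4920 nM, a lower number than compound 1 shows. Hydrogen in place of fluoro gives a 1.8-fold higher number from compound 2 to compound 3 (0.25 log units; within the scatter), so compound 3 stays level with its nearest neighbour.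

Compound 4 `CN(C)CCCn1cccc1/C=N/NC(=O)Nc1ccc(Oc2ccnc3[nH]ccc23)cc1` carries 1-(3-(dimethylamino)propyl)-1H-pyrrol-2-yl in place of 4-hydroxyphenyl on a carbon with a double bond to nitrogen. For the measured compounds named here, the one measured change at this place, 4-hydroxyphenyl in place of 3,4-dichlorophenyl, gives a 5.1-fold lower number from compound 1 to compound 2 (0.71 log units; beyond the scatter). Changes here can therefore shift the number, but no measured compound carries the entering group, so no step beyond the scatter is expected in this assay. The expected result is a 1.6-fold lower number from compound 3 to compound 4 (0.21 log units; within the scatter). For compound 4 the estimated value is 3000 nM, with an expected range of 800 nM to 11000 nM.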

Compound 4, half-maximal inhibitory concentration: 5150 nM
Compound 4: middle estimate off by 1.7-fold (0.23 log units), on the low side; the range from low to high includes it.
By their numbers in this assay, from the lowest: compounds 2, 3 and 4 (each within the scatter of the next); then compound 1.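

In this assay, 1-(3-(dimethylamino)propyl)-1H-pyrrol-2-yl in place of 4-hydroxyphenyl gives a 1.0-fold higher number from compound 3 to compound 4 (0.02 log units; within the scatter), so not every change at this place shifts the number, even though the entering group has more heavy atoms, a five-membered aromatic ring and no hydrogen-bond donors. The hydrogen-bond donor of 4-hydroxyphenyl is therefore not required to hold the number level in this pair. Nothing measured here explains why these two groups read alike. Still open, going by these compounds, is whether a longer chain, or a carboxylic acid in place of the dimethylamino group, would keep the number level.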